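Heteroaryl amide swap on the shared core

The source may report more compounds than this note shows. Statements on the series, on what has been measured and on what is new or still open speak of the compounds shown alone.

- compound 1 `CCCCCCCCCCCC[C@@H](O)[C@H]1CC[C@H]([C@H](O)CCCCCCCCCCNC(=O)c2ccco2)O1`: 100000 nM
- compound 2 `CCCCCCCCCCCC[C@@H](O)[C@H]1CC[C@H]([C@H](O)CCCCCCCCCCNC(=O)c2cncs2)O1`: 100000 nM
- compound 3 `CCCCCCCCCCCC[C@@H](O)[C@H]1CC[C@H]([C@H](O)CCCCCCCCCCNC(=O)c2ccnn2C)O1`: not yet measured

In a functional assay on HBC5 cells (Homo sapiens) for inhibition, read by colorimetric assay and sulforhodamine B assay, with a stated time of 48 h (a higher number here means a weaker inhibitor of growth, a lower number a stronger inhibitor of growth), compound 2 gives 100000 nM, level with compound 1, its nearest neighbour. The next change puts 1-methyl-1H-pyrazol-5-yl in place of 1,3-thiazol-5-yl on a carbonyl carbon. Among the compounds with values here, one measured step bears on this, no change at the digits printed from compound 1 to compound 2 (within the scatter). It also exchanged one aromatic ring for another on a carbonyl carbon. Within the data shown here, no measured compound carries the 1-methyl-1H-pyrazol-5-yl group, so the expectation rests on that single step and on compound 2 at 100000 nM. The expected result in this assay is no change at the digits printed from compound 2 to compound 3 (within the scatter), with no step beyond the scatter and no direction favoured. The estimate for compound 3 is 100000 nM, with an expected range of 40000 nM to 120000 nM.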

Compound 3, concentration for 50% growth inhibition: 17000 nM
The estimate for compound 3 lay 5.9-fold (0.77 log units) above the measured number; the measured number lies below the stated range.
By their numbers in this assay, from the lowest: compound 3; then compounds 1 and 2 (each within the scatter of the next).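

In this assay, the aromatic ring on the carbonyl carbon now shows that it can affect growth inhibition: 1-methyl-1H-pyrazol-5-yl gives a 5.9-fold lower number from compound 2 to compound 3 (0.77 log units; beyond the scatter) and a 5.9-fold lower number from compound 1 to compound 3 (0.77 log units; beyond the scatter), whereas the earlier ring exchange gave no step beyond the scatter. The leaving 1,3-thiazol-5-yl and entering 1-methyl-1H-pyrazol-5-yl have the same printed counts of ring hetero atoms, hydrogen-bond donors and hydrogen-bond acceptors, so those counts do not separate them, although the exchange also replaces sulfur with nitrogen and adds a methyl group. Nothing available accounts for the lower number.

From the compounds shown here alone, whether the step belongs to the pyrazole ring or to its methyl group remains open. A pyrazole ring without the methyl group, or one carrying an ethyl group instead, would bear on that question.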